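The compounds below may be only part of what the source reports. "The series", "measured", "known", "first", "only" and "open" are said of these compounds alone.

Compound 1 `CC1CCN(C2CCN(S(=O)(=O)c3cccc(Br)c3)CC2)CC1` gives 3.2 nM in a functional assay on DLD-1 cells (Homo sapiens) for antiproliferative activity, read by CellTiter-Glo, with a stated time of 72 h; a lower number here means a stronger inhibitor, a higher number a weaker inhibitor.
Compound 2 `CC1CCN(C2CCN(S(=O)(=O)c3cn(C)cn3)CC2)CC1` gives only a limit in this assay, > 5000 nM.
Compound 3 `CCc1ccc(S(=O)(=O)N2CCC(N3CCC(C)CC3)CC2)cc1` gives only a limit in this assay, > 5000 nM.

Among the compounds with values here, compound 1 stands as the sole number in this assay; the other two values sit at a limit (the limit of > 5000 nM in this assay, at which 2 of the 3 values shown sit). Compound 4 `Cc1ccc(-c2cccc(S(=O)(=O)N3CCC(N4CCC(C)CC4)CC3)c2)cc1` differs from compound 1 by 4-methylphenyl in place of bromo on an aromatic carbon.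

Within the data shown here, the steps that bear on this are the two other changes of the group on the sulfonyl sulfur: an at least 1500-fold higher number from compound 1 to compound 2 (3.19 log units; beyond the scatter) and an at least 1500-fold higher number from compound 1 to compound 3 (3.19 log units; beyond the scatter). Both were large, but neither kept a substituent meta to a large group as compound 4 does. A step beyond the scatter toward a weaker inhibitor is therefore expected, smaller than those two. Compound 4 is expected at 30 nM (range 5 nM to 600 nM), an expected step of a 9.4-fold higher number from compound 1 to compound 4 (0.97 log units; beyond the scatter).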

Compound 4, half-maximal inhibitory concentration: 11 nM
Compound 4: middle estimate off by 2.7-fold (0.44 log units), on the high side, and the stated range covers the measured number.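

On the aromatic carbon meta to a large group, 4-methylphenyl in place of bromo gives only a 3.4-fold higher number from compound 1 to compound 4 (0.54 log units; beyond the scatter), so in this assay this position carries a whole added aromatic ring and still gives a number rather than a limit. The two changes on the sulfonyl sulfur showed only loss, and compounds 2 and 3 each stand at a limit, not a number: the limit of > 5000 nM in this assay, at which 2 of the 4 values shown sit.

Bromo and 4-methylphenyl are the only groups shown at this position. From the compounds shown here alone, whether plain phenyl, an amine or a carboxylic acid there would hold the number remains open.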